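Nitro for methyl on the sulfonyl phenyl: working notes

This account rests on a few compounds, and the source may have more. Where it says the series, first, only, none or still open, it means among the compounds named here.

Two compounds of the series have numbers in an ADME assay on HEK-293T cells (Homo sapiens) for inhibition, read by CCK-8 assay, with a stated time of 48 h, tested at 20 uM; a higher number here means more inhibition of growth at the concentration tested, a lower number less inhibition of growth. Compound 1 `N#C/C(=C\c1ccccc1OS(=O)(=O)c1ccc([N+](=O)[O-])cc1)C(=O)Nc1nnc(-c2cccs2)s1` gives 33% in this assay. Among the measured compounds shown here, compound 2 `Cc1ccc(S(=O)(=O)Oc2ccccc2/C=C(\C#N)C(=O)Nc2nnc(Cc3ccccc3)s2)cc1` gives 15% in this assay, the lowest of the two numbers; the only other number, that of compound 1, stands higher by more than the scatter. For the measured compounds named here, the two measured compounds differ in two places at once, so no single step between them can be read.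

Compound 3 `N#C/C(=C\c1ccccc1OS(=O)(=O)c1ccc([N+](=O)[O-])cc1)C(=O)Nc1nnc(Cc2ccccc2)s1` is not yet measured. It differs from compound 2 in one place: nitro in place of methyl on an aromatic carbon. Cut one bond further out, the change reads (4-methylphenyl)sulfonyl to (4-nitrophenyl)sulfonyl. Compound 1 carries that same (4-nitrophenyl)sulfonyl group and gives 33% in this assay, but it also differs from compound 3 elsewhere, so it is only a loose pointer. The step from compound 2 to compound 3 is expected as a number 10 percentage points higher from compound 2 to compound 3 (within the scatter), a rise that may or may not exceed the scatter. Compound 3 is expected to give 25% in this assay, within 10% to 42%.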

Compound 3, percent growth inhibition at one concentration: "not toxic" (no number reported)
Compound 3 has no reported number here; no gap can be computed for the estimate.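

Among the compounds shown here, compound 3 is reported in this assay only as "not toxic", without a number, so no step from compound 2 to compound 3 can be read. The compounds shown leave open how far the change from (4-methylphenyl)sulfonyl to (4-nitrophenyl)sulfonyl alone shifts growth inhibition. No evidence bearing on this result is available.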